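Adding a methyl to the benzamide ring of compound 2

The compounds below may be only part of what the source reports. "The series", "measured", "known", "first", "only" and "open" are said of these compounds alone.

Measured compounds:
- compound 1, `CCCc1nc2c(-c3ccc(Cl)cc3)n[nH]c2c(=O)n1NC(=O)c1ccccc1`: 91.1%
- compound 2, `CCCCCc1nc2c(-c3ccc(Cl)cc3)n[nH]c2c(=O)n1NC(=O)c1ccccc1`: 90.1%

In a functional assay on HT-29 cells (Homo sapiens) for cytotoxicity, read by sulforhodamine B assay, with a stated time of 2 days, tested at 100 uM (on this read-out lower numbers stand for less inhibition and higher numbers for more inhibition at the one concentration tested (going by the name of the read-out)), compound 1 gives 91.1% and compound 2 gives 90.1%. Among the compounds with values here, compound 2 stands at the lower of the two numbers, but the one step between them, a number 1 percentage points lower from compound 1 to compound 2 (within the scatter), lies within the scatter, so the two compounds cannot be told apart on this read-out.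

Compound 3, `CCCCCc1nc2c(-c3ccc(Cl)cc3)n[nH]c2c(=O)n1NC(=O)c1cccc(C)c1`, differs from compound 2 by methyl in place of hydrogen on an aromatic carbon. Within the data shown here, no measured step concerns a change on this ring: the only step recorded, a number 1 percentage points lower from compound 1 to compound 2 (within the scatter), alters the saturated chain on the other side of the shared core and left the number essentially where it was. The data therefore offer no direct guide to the effect of a methyl on the benzamide ring, and the expectation rests only on compound 2 itself.

Compound 3 is expected to give 89%, with a range of 75% to 98%. This estimate means a step of a number 1.1 percentage points lower from compound 2 to compound 3 (within the scatter), no change beyond the scatter.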

Compound 3, a percentage reported as inhibition, at one concentration (the size of the read-out at that concentration, not a potency): 90.5%
Beside the measured number, compound 3's estimate is 1.5 percentage points below it; the range from low to high includes it.
By their numbers in this assay, from the lowest: compounds 2, 3 and 1 (each within the scatter of the next).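

In this assay, within the data shown here, the step for this methyl reads a number 0.4 percentage points higher from compound 2 to compound 3 (within the scatter) and is the first reading on the benzamide ring itself, since the earlier pair spoke only to the saturated chain on the other side of the shared core. The two compounds cannot be told apart, so on this read-out a methyl can take the place of hydrogen on this aromatic carbon, meta to a large group, with no difference that rises above the scatter. Nothing measured here speaks to the reason for this result.

One small group at one place says little about the rest of the ring: an amine, a carboxylic acid or a trifluoromethyl on this same carbon might read differently, and so might a methyl elsewhere on the ring. From the compounds shown here alone, all three compounds also lie within the scatter of their neighbours at the one concentration tested, so it remains open whether they would separate at lower concentrations.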